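The source may report more compounds than this note shows. Statements on the series, on what has been measured and on what is new or still open speak of the compounds shown alone.

Two compounds of a shared core have been examined in an assay on isolated protein for binding affinity to 5-hydroxytryptamine receptor 7 (Homo sapiens); on this read-out higher numbers stand for weaker inhibition and lower numbers for stronger inhibition. Compound 1 `O=C1CC(CN2CCC(Oc3ccccc3)CC2)CCc2ccccc21` gives 18.6 nM in this assay. Compound 2 `O=C1c2ccccc2CCCC1CCN1CCC(Oc2ccccc2)CC1` gives 25.1 nM in this assay. Of the two numbers, compound 2 holds the higher one, but the gap to compound 1 lies within the scatter of repeated measurements, so the two compounds cannot be told apart on these data.

The next step moves from compound 2 to compound 3 `Cc1ccccc1OC1CCN(CCC2CCCc3ccccc3C2=O)CC1`. Within the data shown here, the single structural change is methyl in place of hydrogen on an aromatic carbon of a six-membered aromatic ring of carbon only, ortho to a large group. Viewed one bond further out, the phenoxy group of compound 2 becomes a 2-methylphenoxy group in compound 3.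

Among the measured compounds shown here, no measured pair in this set shows what such an added methyl does in this assay, so there is no step to lean on. For compound 3 the expected change is a 1.0-fold lower number from compound 2 to compound 3 (0.00 log units; within the scatter), a step not expected to go beyond the usual scatter in either direction. Compound 3 is therefore estimated at 25 nM in this assay, with a range from 8 nM to 80 nM.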

Compound 3, inhibition constant: 11.2 nM
For compound 3 the middle estimate is 2.2-fold (0.35 log units) above the measured one; low and high end bracket the measured number.
By their numbers in this assay, from the lowest: compounds 3, 1 and 2 (each within the scatter of the next, the first and the last beyond it).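

In this assay, methyl in place of hydrogen on an aromatic carbon, ortho to a large group, goes with a 2.2-fold lower number from compound 2 to compound 3 (0.35 log units; beyond the scatter), a modest step. Among these compounds, this is the first sign that the phenoxy group is open to change: turning it into a 2-methylphenoxy group, with a single added carbon, moves the number beyond the scatter, something compound 1 and compound 2 could not show, since they differ elsewhere and cannot be told apart. The step rests on this one pair, and no measurement among these compounds gives a reason for it.

As far as these compounds go, it remains open whether another group in the same place, such as ethyl, methoxy or chlorine, would bring a similar step, or whether methyl would do so at another aromatic carbon of the phenoxy group. Also open, from the compounds shown here alone, is whether turning the phenoxy group of compound 1 into a 2-methylphenoxy group would bring a step of similar size on that compound, so that the change could be read in a second pair.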